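Aryl group change at the amide-type nitrogen

The source may report more compounds than this note shows. Statements on the series, on what has been measured and on what is new or still open speak of the compounds shown alone.

Measured compounds:
compound 1 `CC1(C)CC(NC(=S)Nc2cccc(C#N)c2)c2cc(Br)ccc2O1` — 7000 nM
compound 2 `CC1(C)CC(NC(=S)Nc2cccc(Cl)c2)c2cc(Br)ccc2O1` — 7000 nM
compound 3 `COc1ccccc1NC(=S)NC1CC(C)(C)Oc2ccc(Br)cc21` — "not determined" (no result reported)

In a functional assay on B16-F10 cells (Mus musculus) for inhibition, read by MTT assay, with a stated time of 72 h (a lower number here means a stronger inhibitor, a higher number a weaker inhibitor), compound 1 gives 7000 nM, and compound 2 gives 7000 nM; no change at the digits printed from compound 1 to compound 2 (within the scatter). Among the measured compounds shown here, compound 3 gives "not determined" (no result reported) in this assay, so no step can be drawn from it.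

Compound 4 `CC1(C)CC(NC(=S)Nc2ccc(Cl)cc2)c2cc(Br)ccc2O1` follows from compound 3 by one change: 4-chlorophenyl in place of 2-methoxyphenyl on an amide-type nitrogen.

For the measured compounds named here, the only measured step, the one from compound 1 to compound 2, also swaps a group on the aromatic ring attached to the amide-type nitrogen and stayed within the scatter. Compound 2 already carries a chlorophenyl there and sits at the same level as compound 1. Nothing measured separates a 2-methoxyphenyl from either of these, so no direction can be read for compound 4; the expectation is simply a value in the range where compound 1 and compound 2 lie. For compound 4 the estimate in this assay is 7000 nM, expected to fall between 2500 nM and 20000 nM.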

Compound 4, half-maximal inhibitory concentration: 7000 nM
Compound 4: the middle estimate sits on the measured number at the digits printed; low and high end bracket the measured number.
By their numbers in this assay, from the lowest: compounds 1, 2 and 4 (each within the scatter of the next).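

In this assay the chlorine on the aromatic ring has now been tested in a second place, and 4-chlorophenyl in place of 3-chlorophenyl shows no change at the digits printed from compound 2 to compound 4 (within the scatter) on this amide-type nitrogen. Compared with the nitrile-bearing aryl group, 4-chlorophenyl in place of 3-cyanophenyl shows no change at the digits printed from compound 1 to compound 4 (within the scatter) as well, so the two chlorophenyl groups and the 3-cyanophenyl group all stand level here. No available measurement speaks to why these values coincide.

Compound 3 carries no number, so its step to compound 4 cannot be read and the 2-methoxyphenyl group remains unplaced. Also open, on these data alone, is whether any change on this nitrogen moves the value, for example an aminophenyl group, a carboxylic acid on the aromatic ring, or a cyclohexyl group in place of the aromatic ring.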